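A side-chain change starting from an assay limit

The source may report more compounds than this note shows. Statements on the series, on what has been measured and on what is new or still open speak of the compounds shown alone.

Measured in a functional assay on HeLa cells (Homo sapiens) for antiproliferative activity, read by MTT assay, with a stated time of 48 h; on this read-out higher numbers stand for weaker inhibition and lower numbers for stronger inhibition:
Compound 1 `CCN(CC)CCn1c(N)c(-c2nc3ccccc3[nH]2)c2nc(C#N)c(C#N)nc21` gives 11600 nM
Compound 2 `CN1CCN(CCn2c(N)c(-c3nc4ccccc4[nH]3)c3nc(C#N)c(C#N)nc32)CC1` gives > 50000 nM as a limit of the assay

Going by the values given here, compound 2 has no exact number and stands at the limit of > 50000 nM in this assay, at which 1 of the 2 values shown sits, as its only reading. Going from compound 2 to compound 3 `CN(C)CCCn1c(N)c(-c2nc3ccccc3[nH]2)c2nc(C#N)c(C#N)nc21`, the change (dimethylamino)methyl in place of 4-methylpiperazin-1-yl on a saturated chain carbon, two bonds along the chain from an aromatic nitrogen puts (dimethylamino)methyl in place of 4-methylpiperazin-1-yl on a saturated chain carbon, two bonds along the chain from an aromatic nitrogen. Among the compounds with values here, the one measured step bearing on this is an at least 4.3-fold higher number from compound 1 to compound 2 (0.63 log units; beyond the scatter) with 4-methylpiperazin-1-yl entering in place of diethylamino, so a step of similar size toward lower numbers is expected in this assay when that group leaves. The expected change is an at least 3.5-fold lower number from compound 2 to compound 3 (0.55 log units; beyond the scatter) by this estimate. Compound 3 is estimated at 14000 nM with 4000 nM to 50000 nM as its expected range.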

Compound 3, half-maximal inhibitory concentration: 25900 nM
Compound 3: middle estimate off by 1.9-fold (0.27 log units), on the low side, within the range that was stated.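

In this assay, putting 3-(dimethylamino)propyl in place of 2-(4-methylpiperazin-1-yl)ethyl brings the read-out to a measured number, with an at least 1.9-fold lower number from compound 2 to compound 3 (0.28 log units; that floor lies within the scatter). That step is only a floor, as compound 2 is a limit of the assay: the limit of > 50000 nM in this assay, at which 1 of the 3 values shown sits. The same side chain still falls short of the diethylamino chain, with a 2.2-fold higher number from compound 1 to compound 3 (0.35 log units; beyond the scatter), so the position tolerates neither replacement without a loss.

Since the chain length and the amine change together here, their contributions remain unseparated. A 2-(dimethylamino)ethyl chain, or a pyrrolidine at the chain end, would bear on this.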